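A few compounds are considered here, and "the series" means these few. Any claim that something is new, unique, unknown or untested is made for them only; others in the source may bear on it.

Measured so far:
compound 1, `COc1ccc(OCCCON2C(N)=NC(N)=NC23CCOCC3)cc1` — > 90%
compound 2, `NC1=NC2(CCSCC2)N(OCCCOc2ccc(Br)cc2)C(N)=N1` — > 90%

In an assay on isolated protein for inhibition of Dihydrofolate reductase (Homo sapiens), read by spectrophotometry, using NADPH, with stated times of 5 s and 6 min, tested at 5 uM (a lower number here means a weaker effect, a higher number a stronger effect of the compound at the concentration tested), compound 1 gives > 90%, which is a limit of the assay rather than a number. In this assay compound 2 gives > 90%, likewise a limit. The picture is uniform: the limit of > 90% in this assay, at which 2 of the 2 values shown sit. No step between two measured compounds is available, so the shown numbers tell only that both measured compounds reach the limit.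

Compound 3, `NC1=NC2(CCOCC2)N(OCCCOc2ccc(F)cc2)C(N)=N1`, has not yet been measured. It differs from compound 1 by fluoro in place of methoxy on an aromatic carbon. Given that compound 1 sits at the limit and that the only other measured compound also sits there, the expected step that the limit leaves unreadable from compound 1 to compound 3 is none beyond the scatter. Compound 3 is therefore expected to give about 92% in this assay, in a range from 75% to 99%, most likely reported again as a limit.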

Compound 3, a percentage reported as inhibition, at one concentration (the size of the read-out at that concentration, not a potency): > 90%
Compound 3: no number, only a limit (the forecaster's own chance of this, stated with the estimate: 70%); the middle value lies beyond the limit too.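

Compound 1 and compound 3 both stand at a limit in this assay, so fluoro in place of methoxy yields no readable step between them: the limit of > 90% in this assay, at which 3 of the 3 values shown sit.
The compounds shown leave open how compound 1, compound 2 and compound 3 actually compare in inhibition at the concentration tested.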